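The compounds below may be only part of what the source reports. "The series", "measured", "known", "first", "only" and "open" are said of these compounds alone.

In a functional assay on MCF7 cells (Homo sapiens) for inhibition, read by sulforhodamine B assay (on this read-out higher numbers stand for weaker inhibition of growth and lower numbers for stronger inhibition of growth), compound 1 (`COc1ccc(-c2ccc(-c3ccc(-c4nc5cc(C)ccc5[nH]4)cc3)cc2)cc1OC`) gives 190 nM and compound 3 (`COc1ccc(-c2ccc(-c3ccc(-c4nc5c(O)cccc5[nH]4)cc3)cc2)cc1OC`) gives 190 nM while compound 2 (`Oc1cccc2[nH]c(-c3ccc(-c4ccc(-c5ccc(C(F)(F)F)cc5)cc4)cc3)nc12`) gives 2310 nM as the highest of the three numbers. Compound 4 (`Cc1ccc2[nH]c(-c3ccc(-c4ccc(-c5ccc(C(F)(F)F)cc5)cc4)cc3)nc2c1`) differs from compound 2 in one place, by 5-methyl-1H-benzimidazol-2-yl in place of 4-hydroxy-1H-benzimidazol-2-yl on an aromatic carbon and so carries 5-methyl-1H-benzimidazol-2-yl in place of 4-hydroxy-1H-benzimidazol-2-yl on an aromatic carbon. The same two groups are exchanged, in the opposite direction and with 3,4-dimethoxyphenyl on the other end of the molecule, in the step of no change at the digits printed from compound 1 to compound 3 (within the scatter) which lies within the scatter. The large step of a 12-fold lower number from compound 2 to compound 3 (1.08 log units; beyond the scatter) instead replaces 4-(trifluoromethyl)phenyl, a group that compound 4 keeps, so it does not apply to this change. Going by the values given here, no measured pair tests the exchange with 4-(trifluoromethyl)phenyl present. No shift beyond the scatter is therefore expected in this assay and the estimated step is a 1.0-fold lower number from compound 2 to compound 4 (0.00 log units; within the scatter) with neither direction favoured. For compound 4 the estimated value is 2300 nM with an expected range of 1000 nM to 5000 nM on repeated measurement.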

Compound 4, concentration for 50% growth inhibition: 31000 nM
For compound 4 the middle estimate is 13-fold (1.13 log units) below the measured one; measured number outside the range, above it.
By their numbers in this assay, from the lowest: compounds 1 and 3 (each within the scatter of the next); then compound 2; then compound 4.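

In this assay, the exchange between 4-hydroxy-1H-benzimidazol-2-yl and 5-methyl-1H-benzimidazol-2-yl matters when 4-(trifluoromethyl)phenyl stands at the other end, with a 13-fold higher number from compound 2 to compound 4 (1.13 log units; beyond the scatter), so its silence with 3,4-dimethoxyphenyl does not carry over: the same change on two cores in this assay, no change at the digits printed (within the scatter) from compound 1 to compound 3 and a 13-fold lower number (1.13 log units; beyond the scatter) from compound 4 to compound 2, 13-fold (1.13 log units) apart, beyond the scatter of two such steps

Seen from the other end, 4-(trifluoromethyl)phenyl in place of 3,4-dimethoxyphenyl gives a 160-fold higher number from compound 1 to compound 4 (2.21 log units; beyond the scatter), a larger step than on the core of compound 3: the same change on two cores in this assay, a 12-fold lower number (1.08 log units; beyond the scatter) from compound 2 to compound 3 and a 160-fold lower number (2.21 log units; beyond the scatter) from compound 4 to compound 1, 13-fold (1.13 log units) apart, beyond the scatter of two such steps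

Across these four compounds, the two ends of the molecule therefore do not act independently.

The compounds shown do not separate the part played by the hydroxy group from that of the methyl group, as these two groups differ in both kind and place. They also leave open how an amine or a carboxylic acid in place of either group would behave with each of the two aryl ends.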